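The source may report more compounds than this note shows. Statements on the series, on what has been measured and on what is new or still open speak of the compounds shown alone.

Measured so far in a functional assay on SMMC-7721 cells (Homo sapiens) for cytotoxicity, read by MTT assay, with a stated time of 4 days; a lower number here means a stronger inhibitor, a higher number a weaker inhibitor:

Compound 1 `C=C1C(=O)[C@]23C[C@@]1(O)CC[C@H]2c1ccc(O)c(C)c1[C@@H]3Cn1cc(-c2ccc(F)cc2)nn1` gives 850 nM.
Compound 2 `C=C1C(=O)[C@]23C[C@@]1(O)CC[C@H]2c1ccc(O)c(C)c1[C@@H]3Cn1cc(-c2ccc(C)cc2)nn1` gives 920 nM.
Compound 3 `C=C1C(=O)[C@]23C[C@@]1(O)CC[C@H]2c1ccc(OS(=O)(=O)c2ccc(C)cc2)c(C)c1[C@@H]3Cn1cc(-c2ccc(F)cc2)nn1` gives 4280 nM.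

Compound 1 and compound 2 differ only in methyl in place of fluoro on an aromatic carbon, and the step of a 1.1-fold higher number from compound 1 to compound 2 (0.03 log units; within the scatter). Compound 3 differs from compound 1 in (4-methylphenyl)sulfonyl in place of hydrogen on an oxygen on an aromatic ring, and that step a 5.0-fold higher number from compound 1 to compound 3 (0.70 log units; beyond the scatter).

Compound 4 `C=C1C(=O)[C@]23C[C@@]1(O)CC[C@H]2c1ccc(OS(=O)(=O)c2ccc(C)cc2)c(C)c1[C@@H]3Cn1cc(-c2ccc(C)cc2)nn1` is not yet measured in this assay. It stands to compound 3 as compound 2 stands to compound 1: the change is methyl in place of fluoro on an aromatic carbon, the same change, at the same kind of place, as seen between compound 1 and compound 2.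

Since that change moved the number within the scatter in the pair of compound 1 and compound 2, the expected step from compound 3 to compound 4 is about as small, a 1.1-fold higher number from compound 3 to compound 4 (0.03 log units; within the scatter), resting on a 1.1-fold higher number from compound 1 to compound 2 (0.03 log units; within the scatter). Compound 4 is therefore expected to give about 4600 nM, with a range of 2400 nM to 9000 nM.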

Compound 4, half-maximal inhibitory concentration: 4410 nM
The estimate for compound 4 lay 1.0-fold (0.02 log units) above the measured number; the range from low to high includes it.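

In this assay, the change from 4-fluorophenyl to 4-methylphenyl on the core of compound 3 gives a 1.0-fold higher number from compound 3 to compound 4 (0.01 log units; within the scatter), and it carries over from the core of compound 1: the same change on two cores in this assay, a 1.1-fold higher number (0.03 log units; within the scatter) from compound 1 to compound 2 and a 1.0-fold higher number (0.01 log units; within the scatter) from compound 3 to compound 4, 1.1-fold (0.02 log units) apart, within the scatter of two such steps

The (4-methylphenyl)sulfonyl group on the oxygen likewise carries across both aryl groups, with a 4.8-fold higher number from compound 2 to compound 4 (0.68 log units; beyond the scatter): the same change on two cores in this assay, a 5.0-fold higher number (0.70 log units; beyond the scatter) from compound 1 to compound 3 and a 4.8-fold higher number (0.68 log units; beyond the scatter) from compound 2 to compound 4, 1.1-fold (0.02 log units) apart, within the scatter of two such steps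

In these four compounds the two changes therefore add up independently, but this does not show that either change would carry to a core outside this set or that the same would hold for other groups.

Among these compounds, each place shows only two groups. Open, on these data alone, are an amine or a carboxylic acid in place of fluoro on that aromatic ring, and a methylsulfonyl or acetyl group on the oxygen.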